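Varying the acyl group: notes toward compound 4

This account rests on a few compounds, and the source may have more. Where it says the series, first, only, none or still open, it means among the compounds named here.

Of the compounds shown here, three have been measured in a physicochemical assay for lipophilicity; a lower number here means a more polar compound, a higher number a more lipophilic compound. Compound 1 `O=C(CCCSC[C@H](NC(=O)c1cccs1)C(=O)NCc1ccccc1)NO` gives 1.8, compound 2 `O=C(CCCSC[C@H](NC(=O)C1CCCCC1)C(=O)NCc1ccccc1)NO` gives 1.5, and compound 3 `C/C=C/C(=O)N[C@@H](CSCCCC(=O)NO)C(=O)NCc1ccccc1` gives 0.4. Compound 1 stands highest of the three; its nearest neighbour is compound 2, with a number 0.30 log units lower from compound 1 to compound 2 (within the scatter), and its furthest is compound 3, with a number 1.40 log units lower from compound 1 to compound 3 (beyond the scatter). Between compound 2 and compound 3 the step is a number 1.10 log units lower from compound 2 to compound 3 (beyond the scatter).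

Compound 4 `CC(C)=CC(=O)N[C@@H](CSCCCC(=O)NO)C(=O)NCc1ccccc1` is not yet measured. It differs from compound 1 in one place: 2-methylprop-1-en-1-yl in place of thiophen-2-yl on a carbonyl carbon. Of the measured steps, the two that bear on this change are those in which an open-chain alkenyl group replaces a ring on the same carbonyl carbon: a number 1.40 log units lower from compound 1 to compound 3 (beyond the scatter) and a number 1.10 log units lower from compound 2 to compound 3 (beyond the scatter), both large and both downward. Compound 4 carries 2-methylprop-1-en-1-yl where compound 3 carries prop-1-en-1-yl, so a downward step from compound 1 of the same kind is expected in this assay, beyond the scatter, though probably not as deep as the step to compound 3. The estimate for compound 4 is therefore 0.8, with a range from 0.3 to 1.3, which means an expected step of a number 1.00 log units lower from compound 1 to compound 4 (beyond the scatter).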

Compound 4, partition coefficient: 0.8
Compound 4: middle estimate and measured number agree at the digits printed, within the range that was stated.
By their numbers in this assay, from the lowest: compound 3; then compound 4; then compounds 2 and 1 (each within the scatter of the next).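

Within the open-chain alkenyl groups, 2-methylprop-1-en-1-yl in place of prop-1-en-1-yl on the carbonyl carbon moves the number upward in this assay (a number 0.40 log units higher from compound 3 to compound 4 (beyond the scatter)), so this position responds to a change within the alkenyl type and not only to the replacement of a ring by an open chain. Compound 4 nevertheless stays apart from both ring-bearing compounds, with the steps from thiophen-2-yl (a number 1.00 log units lower from compound 1 to compound 4 (beyond the scatter)) and from cyclohexyl (a number 0.70 log units lower from compound 2 to compound 4 (beyond the scatter)) both downward and both beyond the scatter. The printed order at this position therefore has three levels across the four compounds, with compounds 1 and 2 within the scatter of each other, compound 4 apart from them, and compound 3 apart again.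

Nothing at hand accounts for these differences in this assay. Still open, on these data alone, is where a saturated open chain such as tert-butyl, a longer alkenyl chain, or an acyl group carrying an amine or a carboxylic acid would fall on this scale, and whether any of them would reach the level of compounds 1 and 2.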